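The source may hold more compounds than are shown below. What is called first, only, known or untested is meant among the compounds shown, and "the series" means these compounds.

Compounds measured so far in a functional assay on HCT-116 cells (Homo sapiens) for antiproliferative activity, read by MTT assay, with a stated time of 48 h (a lower number here means a stronger inhibitor, a higher number a weaker inhibitor), are these two
- compound 1 `CCCCCC(CCO)n1c(Br)nc2c(Cl)ncnc21` with 18300 nM as its value
- compound 2 `CCCCCCC(CCO)n1cnc2c(Cl)ncnc21` with 11900 nM as its value

Compound 2, at 11900 nM in this assay as its reading, lies within the usual scatter of compound 1, so neither can be placed ahead of the other. Compound 3 `CCCCCCC(CCO)n1c(Br)nc2c(Cl)ncnc21` differs from compound 2 by a single change bromo in place of hydrogen on an aromatic carbon with bromo in place of hydrogen on an aromatic carbon. Among the measured compounds shown here, no measured pair shows this change alone, so its effect in this assay is unknown. Compound 1, which also carries bromo, gives 18300 nM as its value, within the scatter of compound 2, so no step beyond the scatter is expected. The estimated change is a 1.1-fold higher number from compound 2 to compound 3 (0.04 log units; within the scatter) in either direction at most within that scatter. For compound 3 the expected value is 13000 nM with an estimated range from 5500 nM to 30000 nM overall.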

Compound 3, half-maximal inhibitory concentration: 16100 nM
Beside the measured number, compound 3's estimate is 1.2-fold (0.09 log units) below it; the range from low to high includes it.
By their numbers in this assay, from the lowest: compounds 2, 3 and 1 (each within the scatter of the next).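

In this assay, among the compounds shown here, the first pair that isolates bromo in place of hydrogen on an aromatic carbon gives a 1.4-fold higher number from compound 2 to compound 3 (0.13 log units; within the scatter) and so shows that, at this position between two ring nitrogen atoms, the bromo group can be carried without a step beyond the scatter. The other new pair, for methyl in place of hydrogen on a saturated chain carbon, gives a 1.1-fold lower number from compound 1 to compound 3 (0.06 log units; within the scatter) with bromo present on both compounds, so this chain difference also stays within the scatter. No measurement is available that would explain either result.

On these data alone, whether an amine at the position carrying bromo, or a longer chain, would give a reading beyond the scatter remains open. As all the steps shown lie within the scatter, they do not yet identify any part of the structure on which the reading in this assay depends.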